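A few compounds are considered here, and "the series" means these few. Any claim that something is new, unique, unknown or untested is made for them only; others in the source may bear on it.

Compound 1 (`O=C(N/N=C/c1cccc(Br)c1)Nc1cc2c(Nc3ccc(F)c(Cl)c3)ncnc2cc1O[C@H]1CCOC1`) gives 15500 nM in a functional assay on PC-3 cells (Homo sapiens) for cytotoxicity, read by MTT assay, with a stated time of 72 h (on this read-out higher numbers stand for weaker inhibition and lower numbers for stronger inhibition), and compound 2 (`O=C(N/N=C/c1ccc(F)cc1Cl)Nc1cc2c(Nc3ccc(F)c(Cl)c3)ncnc2cc1O[C@H]1CCOC1`) gives 28400 nM on the same read-out. Compound 3 (`COc1ccc(/C=N/NC(=O)Nc2cc3c(Nc4ccc(F)c(Cl)c4)ncnc3cc2O[C@H]2CCOC2)c(OC)c1OC`) gives 25600 nM in this assay as well. Compound 2 therefore stands within the scatter of both other compounds, and no order among the three can be read from these numbers.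

The next structure is compound 4 (`O=C(N/N=C/c1cc(Br)c(O)c(Br)c1)Nc1cc2c(Nc3ccc(F)c(Cl)c3)ncnc2cc1O[C@H]1CCOC1`), still unmeasured. It carries 3,5-dibromo-4-hydroxyphenyl in place of 2-chloro-4-fluorophenyl on a carbon with a double bond to nitrogen and keeps the rest of compound 2 unchanged.

All three measured steps are exchanges at this same place: a 1.8-fold higher number from compound 1 to compound 2 (0.26 log units; within the scatter) then a 1.7-fold higher number from compound 1 to compound 3 (0.22 log units; within the scatter) and finally a 1.1-fold lower number from compound 2 to compound 3 (0.05 log units; within the scatter) as the third. None leaves the scatter. For the measured compounds named here, no measured compound carries 3,5-dibromo-4-hydroxyphenyl, so the expectation rests only on these small steps, and it is a weak basis for a group not yet tried.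

No step beyond the scatter is therefore expected in this assay for this exchange. The estimated step is a 1.3-fold lower number from compound 2 to compound 4 (0.11 log units; within the scatter) as the working expectation. For compound 4 the estimated value is 22000 nM with an expected range from 9000 nM to 50000 nM in this assay once measured.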

Compound 4, half-maximal inhibitory concentration: 6160 nM
Compound 4: middle estimate off by 3.6-fold (0.55 log units), on the high side, outside the stated range (below it).
By their numbers in this assay, from the lowest: compound 4; then compounds 1, 3 and 2 (each within the scatter of the next).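

At this position, on a carbon with a double bond to nitrogen, the aryl group can now be seen to matter in this assay: 3,5-dibromo-4-hydroxyphenyl gives steps beyond the scatter against all three earlier groups (a 4.6-fold lower number from compound 2 to compound 4 (0.66 log units; beyond the scatter); a 4.2-fold lower number from compound 3 to compound 4 (0.62 log units; beyond the scatter); a 2.5-fold lower number from compound 1 to compound 4 (0.40 log units; beyond the scatter)), all modest in size, whereas the exchanges among 3-bromophenyl, 2-chloro-4-fluorophenyl and 2,3,4-trimethoxyphenyl stayed within the scatter. Compound 4 therefore stands apart from the other three compounds, and its aryl group is the only one shown with a hydroxyl, which adds a hydrogen-bond donor, while the single bromine of compound 1 leaves that compound within the scatter of compound 2 and compound 3. Nothing available explains why this group gives the lower number.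

The compounds shown do not separate the hydroxyl from the two flanking halogens of the 3,5-dibromo-4-hydroxyphenyl group, so the step may belong to either part or only to the combination. Also open, as far as these compounds go, is how this assay would read a plain 4-hydroxyphenyl, or an amine or a carboxylic acid in place of the hydroxyl.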